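A few compounds are considered here, and "the series" means these few. Any claim that something is new, unique, unknown or untested is made for them only; others in the source may bear on it.

Compound 1 `OC[C@H]1O[C@@H](n2cnc3c(NCc4ccccc4Br)ncnc32)[C@H](O)[C@@H]1O` carries a 2-bromobenzyl group on the shared core. In a functional assay on G-361 cells (Homo sapiens) for antiproliferative activity, with a stated time of 72 h (on this read-out lower numbers stand for stronger inhibition and higher numbers for weaker inhibition), compound 1 gives > 166000 nM, which is a limit of the assay rather than a number. Compound 2 `COc1cccc(CNc2ncnc3c2ncn3[C@@H]2O[C@H](CO)[C@@H](O)[C@H]2O)c1` in this assay gives "not determined" (no result reported). On the numbers shown, compound 1 stands at the limit of > 166000 nM in this assay, at which 1 of the 2 values shown sits, so no single value places it anywhere on the scale. The change leading to compound 3 `OC[C@H]1O[C@@H](n2cnc3c(NCc4ccc(Cl)c(Cl)c4)ncnc32)[C@H](O)[C@@H]1O` is 3,4-dichlorophenyl in place of 2-bromophenyl on a saturated chain carbon bound to a nitrogen on an aromatic ring. Among the measured compounds shown here, no step between measured compounds exists here, so the size of this exchange cannot be read from data; it can only be expected. The expected step is an at least 1.1-fold lower number from compound 1 to compound 3 (0.04 log units; that floor lies within the scatter), that is, none beyond the usual scatter, because the only anchor is the limit in the limit of > 166000 nM in this assay, at which 1 of the 2 values shown sits. Compound 3 is accordingly estimated at 150000 nM, within a range from 40000 nM to 500000 nM, and it is expected that this assay will again report only a limit for compound 3.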

Compound 3, half-maximal inhibitory concentration: 145000 nM
The estimate for compound 3 lay 1.0-fold (0.01 log units) above the measured number, within the range that was stated.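

In this assay compound 3 gives 145000 nM, the only actual number among the compounds shown, so a substituted benzyl group on the shared core can now be placed on the scale. Exchanging 2-bromobenzyl for 3,4-dichlorobenzyl gives an at least 1.1-fold lower number from compound 1 to compound 3 (0.05 log units; that floor lies within the scatter), so nothing shows that this change moves the number beyond the usual scatter. Going by these compounds, the value of compound 1 is a limit, and the true size of the step stays unknown: the limit of > 166000 nM in this assay, at which 1 of the 3 values shown sits.

Compound 2 has no result, so any step involving it cannot be read. On these data alone, whether an amine or a carboxylic acid on the phenyl ring, or a longer chain between that ring and the nitrogen, would bring the number down substantially remains open.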